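This account rests on a few compounds, and the source may have more. Where it says the series, first, only, none or still open, it means among the compounds named here.

Compound 1 `O=C(/C=C/c1ccc(OC(F)(F)F)cc1)c1ccccc1` and compound 2 `O=C(/C=C/c1ccc(OC(F)(F)F)cc1)c1ccccc1O` share one core and differ in a single place. Both have been tested in a functional assay on RAW264.7 cells (Mus musculus) for inhibition, read by fluorescence, with stated times of 1 h, 24 h and 30 min; a lower number here means a stronger inhibitor, a higher number a weaker inhibitor. Compound 1 gives > 10000 nM, which is a limit of the assay and not a number. Compound 2 gives > 10000 nM, which is also a limit. The picture so far is therefore (the limit of > 10000 nM in this assay, at which 2 of the 2 values shown sit), and compound 2 has no exact number of its own.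

The next compound, compound 3 `O=C(/C=C/c1ccc(OC(F)(F)F)cc1)c1cccc(O)c1`, has the same atoms joined differently: 3-hydroxyphenyl in place of 2-hydroxyphenyl on a carbonyl carbon. A 3-hydroxyphenyl takes the place of a 2-hydroxyphenyl on a carbonyl carbon. Among the compounds with values here, the only measured step that bears on this is a step that the two limits leave unreadable from compound 1 to compound 2, with hydroxy in place of hydrogen on an aromatic carbon. That step offers neither a size nor a direction to carry over, so no clear step is expected in this assay. The estimated step is a number no higher from compound 2 to compound 3 (the limit leaves the size open), which is a cautious expectation. For compound 3 the expected value is 10000 nM, with an estimated range from 3000 nM to 30000 nM.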

Compound 3, half-maximal inhibitory concentration: > 10000 nM
Compound 3: only a limit was reported; the forecaster's own chance of this, stated with the estimate: 70%; the middle value lies on the limit itself.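

In this assay compound 3 gives > 10000 nM, which is a limit of the assay and not a number. No step among compound 1, compound 2 and compound 3 can be read: the limit of > 10000 nM in this assay, at which 3 of the 3 values shown sit.

The compounds shown leave open whether 2-hydroxyphenyl or 3-hydroxyphenyl changes the inhibition at all, and where the true value of each compound lies.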